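Trifluorophenyl for Trifluoromethylphenyl: Expected Microsomal Stability

The compounds below may be only part of what the source reports. "The series", "measured", "known", "first", "only" and "open" are said of these compounds alone.

Compound 1 `Clc1ccc(-c2nc(NCCNc3ccccn3)ncc2-c2ncc[nH]2)c(Cl)c1` and compound 2 `Nc1nc(NCCNc2ncc(-c3ncc[nH]3)c(-c3ccc(C(F)(F)F)cc3)n2)ccc1[N+](=O)[O-]` were both tested in an ADME assay on microsomes from liver (Rattus norvegicus) for metabolic stability; a higher number here means that the compound lasts longer, a lower number that the compound disappears faster. For compound 1 the result is a limit of the assay rather than a number, > 0.5 h. For compound 2 the result is likewise a limit, > 0.5 h. Compound 2 thus stands where every measured value stands, namely at the limit of > 0.5 h in this assay, at which 2 of the 2 values shown sit. Compound 3 `Nc1nc(NCCNc2ncc(-c3ncc[nH]3)c(-c3cc(F)c(F)cc3F)n2)ccc1[N+](=O)[O-]` is not yet measured; it differs from compound 2 by 2,4,5-trifluorophenyl in place of 4-(trifluoromethyl)phenyl on an aromatic carbon. Going by the values given here, no measured step covers such a change, so no shift beyond the scatter is expected, and the estimated step is a step that the limit leaves unreadable from compound 2 to compound 3. Compound 3 is expected to give about 0.7 h in this assay, between 0.3 h and 1.6 h.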

Compound 3, half-life: > 0.5 h
Compound 3: only a limit was reported; the forecaster's own chance of this, stated with the estimate: 70%; the middle value is on the limit's open side.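

Compound 2 and compound 3 both sit at a limit of this assay, so no step between them can be read: the limit of > 0.5 h in this assay, at which 3 of the 3 values shown sit.

The compounds shown leave open how long each actually lasts in this assay, and whether 2,4,5-trifluorophenyl in place of 4-(trifluoromethyl)phenyl changes that at all.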